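A few compounds are considered here, and "the series" means these few. Any claim that something is new, unique, unknown or untested is made for them only; others in the source may bear on it.

Compound 1 `CC(CSc1nnc(-c2ccncc2)s1)C(=O)NCc1ccccc1Cl`: in an ADME assay on BHK-21 cells (Mesocricetus auratus) for cytotoxicity, with a stated time of 3 days (a lower number here means that less compound is tolerated, a higher number that more compound is tolerated), compound 1 gives > 50000 nM, which is a limit of the assay and not a number.
Compound 2 `CC(CSc1nnc(-c2ccncc2)s1)C(=O)Nc1ccc(Cl)cc1Cl`: in this assay compound 2 gives > 50000 nM, again a limit of the assay.
Compound 3 `CC(CSc1nnc(-c2ccncc2)s1)C(=O)NCc1ccc(Cl)cc1`: in this assay compound 3 gives "not determined" (no result reported).

Compound 3 therefore stands nowhere on the numbers: it has no result, while two of the three values shown sit at the limit of > 50000 nM in this assay, at which 2 of the 3 values shown sit. The move to compound 4 `CC(CSc1nnc(-c2ccncc2)s1)C(=O)Nc1ccccc1Cl` is 2-chlorophenyl in place of 4-chlorobenzyl on an amide-type nitrogen. For the measured compounds named here, the only measured step, a step that the two limits leave unreadable from compound 1 to compound 2, is unreadable, since both of its ends are limits, so no measured step gives a size for the change to compound 4. What the two measured compounds do show is that both a chlorobenzyl and a dichlorophenyl group on the amide nitrogen were tolerated up to the limit in this assay. The expectation for compound 4 is no readable step beyond the scatter, with the result most likely again a limit. Compound 4 is estimated at 50000 nM in this assay, with a range from 20000 nM to 100000 nM.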

Compound 4, half-maximal cytotoxic concentration: > 50000 nM
Compound 4: a limit, no number; the forecaster's own chance of this, stated with the estimate: 80%; the middle value sits exactly at the limit.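

In this assay compound 4 gives > 50000 nM, which is a limit of the assay and not a number. The steps from compound 1 and from compound 2 to compound 4 join limit to limit and cannot be read. The compounds shown leave open at what concentration any of them harms these cells, and whether the groups on the amide nitrogen differ in this at all.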